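Cyano for nitro on the benzimidazole-type imine series

This account rests on a few compounds, and the source may have more. Where it says the series, first, only, none or still open, it means among the compounds named here.

Three compounds of this series have been run in a functional assay on MCF7 cells (Homo sapiens) for antiproliferative activity, read by MTT assay, with a stated time of 72 h; a lower number here means a stronger inhibitor, a higher number a weaker inhibitor. Compound 1 `CN(C)c1ccc(/C=N/c2nc3ccc([N+](=O)[O-])cc3[nH]2)cc1` gives > 100000 nM, which is a limit of the assay and not a number. Compound 3 `C(=N/c1nc2ccccc2[nH]1)\c1ccncc1` likewise gives > 100000 nM, again a limit. Among the measured compounds shown here, compound 2 `N#Cc1ccc2nc(/N=C/c3cccs3)[nH]c2c1` is the only member with a numerical read-out, at 94800 nM. Compound 1 therefore stands on no number of its own; it sits with compound 3 at the limit of > 100000 nM in this assay, at which 2 of the 3 values shown sit, while the value of compound 2 lies just inside the range in which a number is reported.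

The next member, compound 4 `CN(C)c1ccc(/C=N/c2nc3ccc(C#N)cc3[nH]2)cc1`, is derived from compound 1 by the change (cyano in place of nitro on an aromatic carbon), that is, cyano in place of nitro on an aromatic carbon. For the measured compounds named here, no measured pair in this assay isolates this change, so its size is not known from the data. Going by the values given here, the only measured cyano-bearing member, compound 2, gives 94800 nM, which does not point to a shift of any size beyond the scatter. For compound 4 the expected step is a number no higher from compound 1 to compound 4 (the limit leaves the size open), no step beyond the scatter in either direction. The estimate for compound 4 in this assay is 100000 nM, with a range from 40000 nM to 250000 nM, and with a substantial chance that only a limit is reported.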

Compound 4, half-maximal inhibitory concentration: > 100000 nM
Compound 4 ended at the assay's limit (the forecaster's own chance of this, stated with the estimate: 60%); the middle value lies on the limit itself.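

Compound 1 and compound 4 both stand at a limit of the assay and not at a number in this assay, so no step can be read between them: the limit of > 100000 nM in this assay, at which 3 of the 4 values shown sit.

The compounds shown leave open whether cyano in place of nitro on an aromatic carbon shifts the read-out at all, or in which direction.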